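Replacing the benzothiazolyl sulfide with a methyltetrazolyl sulfide

The source may report more compounds than this note shows. Statements on the series, on what has been measured and on what is new or still open speak of the compounds shown alone.

Notes on a small set sharing one core. Compound 1 `Cn1c(-c2ccc(NC(=O)CCl)cc2)nc(-c2ccccc2)c1-c1ccccc1` carries a chloro group on the chain; in a functional assay on HT-29 cells (Homo sapiens) for cytotoxicity, read by MTT assay, with a stated time of 24 h, tested at 16 ug/mL (a lower number here means a weaker effect, a higher number a stronger effect of the compound at the concentration tested), compound 1 gives 23.7%. Compound 2 `Cn1c(-c2ccc(NC(=O)CSc3nc4ccccc4o3)cc2)nc(-c2ccccc2)c1-c1ccccc1` gives 56.2%, and compound 3 `Cn1c(-c2ccc(NC(=O)CSc3nc4ccccc4s3)cc2)nc(-c2ccccc2)c1-c1ccccc1` gives 47.2%. Compound 3 stands second highest of the three numbers; its nearest neighbour is compound 2, the two being within the scatter, while compound 1 lies beyond the scatter below it.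

Two steps carry information: a number 32.5 percentage points higher from compound 1 to compound 2 (beyond the scatter) and a number 23.5 percentage points higher from compound 1 to compound 3 (beyond the scatter) show that either heteroaryl sulfanyl in place of chloro lifts the read-out well beyond the scatter. The third step, a number 9 percentage points lower from compound 2 to compound 3 (within the scatter), shows that exchanging the one fused bicyclic heteroaryl for the other stays within the scatter.

Compound 4 `Cn1nnnc1SCC(=O)Nc1ccc(-c2nc(-c3ccccc3)c(-c3ccccc3)n2C)cc1` differs from compound 3 as follows: 1-methyl-1H-tetrazol-5-yl in place of 1,3-benzothiazol-2-yl on a sulfur. For the measured compounds named here, no measured step covers the loss of the six-membered carbon-only ring, so the bearing of the earlier steps is indirect. The sulfanyl link that set compounds 2 and 3 apart from compound 1 is kept, so compound 4 is expected to stay above compound 1. For compound 4 a downward step in this assay of a number 11.2 percentage points lower from compound 3 to compound 4 (beyond the scatter) is estimated. Compound 4 is therefore expected to give 36%, within 16% to 58%.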

Compound 4, a percentage reported as activity, at one concentration (the size of the read-out at that concentration, not a potency): 72.5%
Compound 4: middle estimate off by 36.5 percentage points, on the low side, outside the stated range (above it).
By their numbers in this assay, from the lowest: compound 1; then compounds 3 and 2 (each within the scatter of the next); then compound 4.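

In this assay the group on the sulfur proves to be a real variable, which the near-equal pair compound 2 and compound 3 could not show: 1-methyl-1H-tetrazol-5-yl separates from 1,3-benzothiazol-2-yl with a number 25.3 percentage points higher from compound 3 to compound 4 (beyond the scatter) and from 1,3-benzoxazol-2-yl with a number 16.3 percentage points higher from compound 2 to compound 4 (beyond the scatter) in the same direction. The earlier exchange of chloro for a heteroaryl sulfanyl group therefore does not have one fixed size, and here it reaches a number 48.8 percentage points higher from compound 1 to compound 4 (beyond the scatter) as the largest of the three such steps, so the gain depends on which heteroaryl group the sulfur carries. The evidence at hand gives no account of why the smaller single-ring group stands above the two groups with a six-membered carbon-only ring.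

Open, going by these compounds, is whether the 1-methyl group on the tetrazole contributes, which a 1-phenyl-1H-tetrazol-5-yl or a 1-ethyl-1H-tetrazol-5-yl group on the same sulfur would test. Also open, on these data alone, is how the read-out responds to a longer chain between the sulfur and the carbonyl, and, since every number here comes from one concentration, how these compounds rank in potency.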